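This account rests on a few compounds, and the source may have more. Where it says the series, first, only, none or still open, it means among the compounds named here.

Working notes on the series. Going by the values given here, compound 2 `Cc1cc2c(cc1C(=O)N=C(N)N)S(=O)(=O)C(C)(C)C2O` gives 258 nM in a functional assay for inhibition, with Homo sapiens as the target (on this read-out lower numbers stand for stronger inhibition and higher numbers for weaker inhibition), and stands at one end of the two numbers measured so far; the only other, compound 1 `Cc1cc2c(cc1C(=O)N=C(N)N)S(=O)(=O)C(C)(C)C2C`, gives 306 nM in this assay, and the step of a 1.2-fold lower number from compound 1 to compound 2 (0.07 log units; within the scatter) separates them, which is within the scatter, so the two are not distinguished by the data. The next compound, compound 3 `COC1c2cc(C)c(C(=O)N=C(N)N)cc2S(=O)(=O)C1(C)C`, differs from compound 2 by methyl in place of hydrogen on an oxygen on a saturated carbon, that is hydroxy to methoxy. Among the compounds with values here, no measured step touches an oxygen on a saturated carbon, so there is no direct precedent. Within the data shown here, the single step available, from methyl to hydroxy at the saturated ring carbon, was a 1.2-fold lower number from compound 1 to compound 2 (0.07 log units; within the scatter) and within the scatter, which shows this position tolerating a change of group without a shift in the read-out. On that basis a step of a 1.1-fold higher number from compound 2 to compound 3 (0.05 log units; within the scatter) is expected for compound 3, which is no step beyond the scatter in this assay. Compound 3 is therefore estimated at 290 nM in this assay, with a range from 120 nM to 700 nM.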

Compound 3, half-maximal inhibitory concentration: 138 nM
The estimate for compound 3 lay 2.1-fold (0.32 log units) above the measured number, within the range that was stated.
By their numbers in this assay, from the lowest: compounds 3, 2 and 1 (each within the scatter of the next, the first and the last beyond it).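

In this assay the oxygen on this saturated carbon tolerates methyl in place of its hydrogen, with a 1.9-fold lower number from compound 2 to compound 3 (0.27 log units; within the scatter), so hydroxy and methoxy are not distinguished by the data. This saturated ring carbon now also shows its first step beyond the scatter, a 2.2-fold lower number from compound 1 to compound 3 (0.35 log units; beyond the scatter), a modest step for methoxy in place of methyl, whereas the earlier step, a 1.2-fold lower number from compound 1 to compound 2 (0.07 log units; within the scatter), did not separate its pair. The group at this carbon can therefore shift the read-out to a modest degree, although only the two ends of the series separate and compound 2 remains within the scatter of both. Nothing available gives a reason for these numbers.

On these data alone, whether a longer chain on the oxygen, such as ethoxy or propoxy, would extend or reverse the step seen with methoxy remains open. Also open, as far as these compounds go, is how an amine or a carboxylic acid at this saturated ring carbon would compare with hydroxy and methoxy.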